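A few compounds are considered here, and "the series" means these few. Any claim that something is new, unique, unknown or untested is made for them only; others in the source may bear on it.

Values in a functional assay on HeLa cells (Homo sapiens) for inhibition, read by MTT assay, with a stated time of 72 h (on this read-out higher numbers stand for weaker inhibition and lower numbers for stronger inhibition), so far:
- compound 1 `COc1cc(NC(C)CCCNC(=O)Nc2ccc(Br)cc2)c2ncccc2c1` gives 20000 nM
- compound 2 `COc1cc(NC(C)CCCNC(=O)NNC(=O)Nc2ccc(F)cc2)c2ncccc2c1` gives >= 250000 nM (a limit, not a number)

Compound 2 is known only by a limit, which places it at the limit of >= 250000 nM in this assay, at which 1 of the 2 values shown sits, in the data so far.

Compound 3 `COc1cc(NC(C)CCCNC(=O)NNC(=O)Nc2ccc(Cl)cc2)c2ncccc2c1` differs from compound 2 by one change, (chloro in place of fluoro on an aromatic carbon), that is, chloro in place of fluoro on an aromatic carbon, para to a large group.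

Among the measured compounds shown here, the only measured step is large, an at least 12-fold higher number from compound 1 to compound 2 (1.09 log units; beyond the scatter), but it replaces the whole 4-bromophenyl group on an amide-type nitrogen and so does not isolate a halogen exchange. For the measured compounds named here, no measured pair shows a change of halogen alone. Going by the values given here, no large step is therefore expected in this assay, only a small move towards a lower number or none beyond the scatter. Another report as a limit is about as likely as a number.

The expected step is an at least 1.3-fold lower number from compound 2 to compound 3 (0.14 log units; that floor lies within the scatter) in this estimate. For compound 3 the estimated value is 180000 nM, with an expected range of 50000 nM to 300000 nM.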

Compound 3, half-maximal inhibitory concentration: 120000 nM
Estimate against measurement, compound 3: 1.5-fold (0.18 log units) above, and the stated range covers the measured number.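

In this assay, among the compounds shown here, fluoro to chloro on an aromatic carbon, para to a large group, is the first change of halogen alone, and it gives an at least 2.0-fold lower number from compound 2 to compound 3 (0.31 log units; beyond the scatter), so this position responds to the halogen exchange beyond the scatter. Compound 2 is known only by a limit, so that step sets a floor and not a full size: (the limit of >= 250000 nM in this assay, at which 1 of the 3 values shown sits). Replacing 4-bromophenyl with ((4-chlorophenyl)carbamoyl)amino on the amide-type nitrogen still gives a 6.0-fold higher number from compound 1 to compound 3 (0.78 log units; beyond the scatter), so the shift to a higher number relative to compound 1 persists with chloro in place of fluoro, although this step exchanges the halogen as well as adding the extended group and cannot separate the two.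

The halogen comparison rests on a single pair, leaving open whether 4-bromophenyl on the same ((aryl)carbamoyl)amino group would give a still lower number or whether the order stops at chloro. Also open, on these data alone, is how an unsubstituted phenyl, a 4-methoxyphenyl or a 4-aminophenyl would behave at this place, and whether a longer chain on the shared core would alter the effect of the halogen.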